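Acylurea aryl swap on the hydrazone thiazole core

The compounds below may be only part of what the source reports. "The series", "measured", "known", "first", "only" and "open" are said of these compounds alone.

Compound 1, `CN(C(=O)NC(=O)c1ccc(Cl)cc1Cl)c1nc(C(F)(F)F)c(C(=O)N/N=C/c2cccc(C(F)(F)F)c2)s1`, gives 6.11 ug/mL in a functional assay on BCG823 cells (Homo sapiens) for inhibition, read by MTT assay, with a stated time of 72 h; on this read-out higher numbers stand for weaker inhibition and lower numbers for stronger inhibition.
Compound 3, `CN(C(=O)NC(=O)c1ccc(Cl)cc1Cl)c1nc(C(F)(F)F)c(C(=O)N/N=C/c2ccc(C(F)(F)F)cc2)s1`, gives 3.08 ug/mL in this assay.
Compound 2, `CNc1nc(C)c(C(=O)N/N=C/c2ccccc2C(F)(F)F)s1`, reaches only a limit of the assay, > 100 ug/mL in this assay; that is a limit, not a number.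

Among the two numbers recorded, compound 1 stands highest, with compound 3 nearest to it: a 2.0-fold lower number from compound 1 to compound 3 (0.30 log units; within the scatter). Going by the values given here, the one remaining value is the limit of compound 2, which lies at the limit of > 100 ug/mL in this assay, at which 1 of the 3 values shown sits.

Compound 4, `CN(C(=O)NC(=O)c1c(F)cccc1F)c1nc(C(F)(F)F)c(C(=O)N/N=C/c2cccc(C(F)(F)F)c2)s1`, differs from compound 1 only at the acylurea end: 2,6-difluorophenyl in place of 2,4-dichlorophenyl on a carbonyl carbon. Among the compounds with values here, none of the measured steps touches this part of the molecule; the single step that is known, from compound 1 to compound 3, moves the trifluoromethyl group on the hydrazone aryl ring and stays within the scatter. Within the data shown here, compound 2 lacks the whole acylurea and carries a different substituent on the shared core, so it offers no step to this change either.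

With nothing bearing directly on the change, compound 4 is expected to stay close to compound 1, with a step of a 1.3-fold higher number from compound 1 to compound 4 (0.12 log units; within the scatter) in this assay, and an estimate for compound 4 of 8 ug/mL with a range of 3 ug/mL to 25 ug/mL.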

Compound 4, half-maximal inhibitory concentration: 25.9 ug/mL
For compound 4 the middle estimate is 3.2-fold (0.51 log units) below the measured one; the whole stated range lies below it.
By their numbers in this assay, from the lowest: compounds 3 and 1 (each within the scatter of the next); then compound 4. At a limit, above all of these: compound 2.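

The aryl group on the carbonyl carbon proves to be a position where a change registers in this assay: the swap of 2,4-dichlorophenyl for 2,6-difluorophenyl gives a clear loss of inhibition (a 4.2-fold higher number from compound 1 to compound 4 (0.63 log units; beyond the scatter)). The only earlier step, on the hydrazone aryl ring, did not separate its two compounds (a 2.0-fold lower number from compound 1 to compound 3 (0.30 log units; within the scatter)), so this is the first step shown that reaches beyond the scatter, and it comes from the acylurea end of the molecule while the rest of compound 1 stays unchanged. Nothing measured here gives a reason for this loss, as the one available observation, the limit of compound 2, does not concern this change.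

Because the step changes both the halogen and the ring positions it occupies, the compounds shown cannot tell which of the two matters, and 2,4-difluorophenyl and 2,6-dichlorophenyl would be the groups that separate them. From the compounds shown here alone, it also remains open how this position responds to a plain phenyl, or to a non-aryl group such as a morpholine or a short alkyl chain on the same carbonyl carbon.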